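The source may report more compounds than this note shows. Statements on the series, on what has been measured and on what is new or still open speak of the compounds shown alone.

Measured so far in a functional assay on K562 cells (Homo sapiens) for cytotoxicity, read by trypan blue exclusion, with a stated time of 96 h; a lower number here means a stronger inhibitor, a higher number a weaker inhibitor:
compound 1 `COc1ccc(/C=C/S(=O)(=O)Nc2ccc(OC)cc2)cc1` gives 5000 nM
compound 2 `COc1ccc(NS(=O)(=O)/C=C/c2c(F)c(F)c(F)c(F)c2F)cc1` gives 5000 nM
compound 3 `COc1cc(OC)c(/C=C/S(=O)(=O)Nc2ccc(OC)c(F)c2)c(OC)c1` gives 75 nM

Compound 3 has the lowest number of the three, and the numbers of compound 1 and compound 2 both lie beyond the scatter above it. Compound 4 `COc1cc(OC)c(/C=C/S(=O)(=O)Nc2ccc(OC)c(NC(C(=O)O)c3ccccc3)c2)c(OC)c1` has not been measured in this assay. It differs from compound 3 in one place: (carboxy(phenyl)methyl)amino in place of fluoro on an aromatic carbon. Among the compounds with values here, no pair of measured compounds isolates a change of this kind, so its size is not known from the data. Given how much enters for how little leaves, a step beyond the scatter toward a weaker inhibitor is expected, though a step in either direction remains possible; the estimated step is a 6.7-fold higher number from compound 3 to compound 4 (0.82 log units; beyond the scatter). Compound 4 is therefore expected at 500 nM, within 75 nM to 5000 nM.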

Compound 4, half-maximal inhibitory concentration: 300 nM
Compound 4: middle estimate off by 1.7-fold (0.22 log units), on the high side; the range from low to high includes it.
By their numbers in this assay, from the lowest: compound 3; then compound 4; then compounds 1 and 2 (each within the scatter of the next).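

In this assay, replacing fluoro with (carboxy(phenyl)methyl)amino, on the aromatic carbon ortho to a methoxy group, gives a 4.0-fold higher number from compound 3 to compound 4 (0.60 log units; beyond the scatter). Within the data shown here, the place therefore accepts a group of 11 heavy atoms, including a six-membered aromatic ring, at a modest cost, and this is the first size known for a change there. No measurement shown here explains that size.

The compounds shown leave open which part of the entering group carries the step. A plain amino group or a methyl ester at this place would help separate those parts.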